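The compounds below may be only part of what the source reports. "The series", "measured", "known", "first", "only" and "open" are said of these compounds alone.

Compound 1 `Cc1ccc2c(NCc3ccc(NC(=O)C4CCN(Cc5ccccc5)CC4)cc3)nc(N3CCN[C@@H](C)C3)nc2c1`, compound 2 `Cc1ccc2c(NCc3ccc(NC(=O)C4CCN(Cc5ccccc5)CC4)cc3)nc(N3CCCC3)nc2c1` and compound 3 `Cc1ccc2c(NCc3ccc(NC(=O)C4CCN(Cc5ccccc5)CC4)cc3)nc(N(C)CCCN(C)C)nc2c1` share one core and differ only in the group carried on an aromatic carbon of that core.

In a functional assay on SV5A8 cells (Homo sapiens) for cytotoxicity (on this read-out higher numbers stand for weaker inhibition and lower numbers for stronger inhibition), compound 1 gives > 8860 nM, a limit of the assay and not a number. In this assay compound 2 gives > 7790 nM, likewise a limit. In this assay compound 3 gives > 8620 nM, again a limit (the limit of > 8620 nM in this assay, at which 1 of the 3 values shown sits). Compound 3 therefore stands at a limit, and the two other values shown are limits as well; no ordering of the three compounds can be read.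

The steps among the measured compounds are all unreadable: a step that the two limits leave unreadable from compound 1 to compound 2, a step that the two limits leave unreadable from compound 1 to compound 3 and a step that the two limits leave unreadable from compound 2 to compound 3.

Compound 4 `Cc1ccc2c(NCc3ccc(NC(=O)C4CCN(Cc5ccccc5)CC4)cc3)nc(N3CCN(C)CC3)nc2c1` is not yet measured. It differs from compound 3 by 4-methylpiperazin-1-yl in place of (3-(dimethylamino)propyl)(methyl)amino on an aromatic carbon.

For the measured compounds named here, the steps that bear on this change, from compound 2 to compound 3 and from compound 1 to compound 3, give no readable size, so no direction can be drawn from them. Every measured variation at this position has stayed at a limit, and compound 4 is expected to do the same, with an expected step that the limit leaves unreadable from compound 3 to compound 4, none beyond the scatter. The estimate for compound 4 in this assay is 9000 nM, with a range from 3000 nM to 30000 nM, most likely again reported only as a limit.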

Compound 4, half-maximal inhibitory concentration: > 17700 nM
Compound 4: a limit, no number (the forecaster's own chance of this, stated with the estimate: 80%); at least 1.9-fold (0.29 log units) between middle value and limit.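

In this assay compound 4 gives > 17700 nM, a limit of the assay and not a number. For the compounds shown here, with all four values at limits, no step between compound 4 and compound 1, compound 2 or compound 3 can be read. The compounds shown leave open whether any group at this position gives a number rather than a limit in this assay, and how these four groups would rank.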